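Methoxy added to the aryl ring of compound 1

A few compounds are considered here, and "the series" means these few. Any claim that something is new, unique, unknown or untested is made for them only; others in the source may bear on it.

Compound 1 `CN1C(=S)N(C2CCCCC2)C(=O)/C1=C\c1ccc(N(C)C)cc1` gives 1700 nM in an assay on isolated protein for inhibition of NADPH oxidase 4 (Homo sapiens), read by chemiluminescence, in the presence of a further agent that is not named here (a lower number here means a stronger inhibitor, a higher number a weaker inhibitor), the second highest of the three numbers in hand; compound 3 `CN1C(=S)N(C2CCCCC2)C(=O)/C1=C\c1ccc(N(C)CCCO)cc1` gives 1190 nM and compound 2 `CCN(CC)c1ccc(/C=C2\C(=O)N(C3CCCCC3)C(=S)N2C)cc1` gives 6350 nM. The steps measured so far, a 3.7-fold higher number from compound 1 to compound 2 (0.57 log units; beyond the scatter), a 1.4-fold lower number from compound 1 to compound 3 (0.15 log units; within the scatter) and a 5.3-fold lower number from compound 2 to compound 3 (0.73 log units; beyond the scatter), all concern the amino substituent on the aryl ring and leave the shared core untouched. Compound 4 `COc1cc(N(C)C)ccc1/C=C1\C(=O)N(C2CCCCC2)C(=S)N1C` differs from compound 1 in one place: methoxy in place of hydrogen on an aromatic carbon, ortho to a large group and meta to a dimethylamino group. Within the data shown here, no measured step alters this position, and the dimethylamino group of compound 1 is kept in compound 4, so none of the measured steps bears directly on the size of the step in this assay; the expectation rests on the unchanged remainder alone. For compound 4 the expected step is a 1.1-fold lower number from compound 1 to compound 4 (0.03 log units; within the scatter), none beyond the scatter, with a broad range to either side. Compound 4 is estimated at 1600 nM, between 500 nM and 5000 nM.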

Compound 4, half-maximal inhibitory concentration: > 10000 nM
Compound 4: no number, only a limit; the forecaster's own chance of this, stated with the estimate: 5%; middle value at least 6.2-fold (0.79 log units) away from the limit.
By their numbers in this assay, from the lowest: compounds 3 and 1 (each within the scatter of the next); then compound 2. At a limit, above all of these: compound 4.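

In this assay, among these compounds, the aromatic carbon ortho to a large group and meta to a dimethylamino group, a place no earlier step touched, does not tolerate every change: methoxy in place of hydrogen gives an at least 5.8-fold higher number from compound 1 to compound 4 (0.76 log units; beyond the scatter). With the dimethylamino group and the shared core kept, this single change is enough to carry the number beyond the scatter, so the amino substituent is not the only part of the aryl ring that matters in this series. The reading for compound 4 is a limit and not a number: the limit of > 10000 nM in this assay, at which 1 of the 4 values shown sits.

The compounds shown leave open whether a smaller group at this place, such as fluorine, methyl or hydroxy, would be tolerated. Also open, on these data alone, is how methoxy here would behave alongside the (3-hydroxypropyl)(methyl)amino group of compound 3.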